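Moving the amide one carbon away from the ring

This account rests on a few compounds, and the source may have more. Where it says the series, first, only, none or still open, it means among the compounds named here.

Compound 1 `CC(=O)N(C)c1cccc2c1nc(-c1c(F)cccc1F)n2Cc1c(F)cccc1F` is the starting point. In a toxicity assay on CCRF-CEM cells (Homo sapiens) for cytotoxicity (on this read-out lower numbers stand for higher toxicity in this test and higher numbers for lower toxicity in this test), compound 1 gives > 100 uM, which is a limit of the assay rather than a measured number (the limit of > 100 uM in this assay, at which 1 of the 3 values shown sits). Compound 2 `CN(C)C(=O)c1cccc2c1nc(-c1c(F)cccc1F)n2Cc1c(F)cccc1F` gives 80.1 uM in this assay, and compound 3 `CC(C)c1cccc2c1nc(-c1c(F)cccc1F)n2Cc1c(F)cccc1F` gives 27 uM. The change to compound 4 `CC(=O)N(C)Cc1cccc2c1nc(-c1c(F)cccc1F)n2Cc1c(F)cccc1F` is (acetyl(methyl)amino)methyl in place of acetyl(methyl)amino on an aromatic carbon. Among the measured compounds shown here, none of the measured steps makes this exact change. The step of an at least 1.2-fold lower number from compound 1 to compound 2 (0.09 log units; that floor lies within the scatter) exchanges acetyl(methyl)amino for dimethylcarbamoyl and stays within the scatter. The steps of an at least 3.7-fold lower number from compound 1 to compound 3 (0.56 log units; beyond the scatter) and a 3.0-fold lower number from compound 2 to compound 3 (0.47 log units; beyond the scatter) put isopropyl in place of those groups and bring clearly lower numbers. Compound 4 keeps the acetyl(methyl)amino part and only adds a single carbon, so at most a small step toward a lower number is expected, and it may well remain at the limit. The step of an at least 1.1-fold lower number from compound 1 to compound 4 (0.04 log units; that floor lies within the scatter) is the expected outcome. For compound 4 the estimate is 90 uM, between 40 uM and 200 uM.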

Compound 4, half-maximal toxic concentration: 20.6 uM
The estimate for compound 4 lay 4.4-fold (0.64 log units) above the measured number; the measured number lies below the stated range.
By their numbers in this assay, from the lowest: compounds 4 and 3 (each within the scatter of the next); then compound 2. At a limit, above all of these: compound 1.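

On this aromatic carbon, one added carbon matters more than the similar amide atoms suggested: in this assay, (acetyl(methyl)amino)methyl gives an at least 4.8-fold lower number from compound 1 to compound 4 (0.68 log units; beyond the scatter). Among the compounds shown here, compound 1 stands at a limit of the assay, so that step is only a floor: the limit of > 100 uM in this assay, at which 1 of the 4 values shown sits. The earlier compounds suggested that amides stay at higher numbers than isopropyl, but compound 4 goes against this, with a 3.9-fold lower number from compound 2 to compound 4 (0.59 log units; beyond the scatter) and a 1.3-fold lower number from compound 3 to compound 4 (0.12 log units; within the scatter).

On these data alone, it remains open whether a longer chain carrying the same acetyl(methyl)amino group would lower the number further. As far as these compounds go, it is also open whether the carbonyl matters here at all, a question that a plain amine such as dimethylaminomethyl on the same carbon could address.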